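This account rests on a few compounds, and the source may have more. Where it says the series, first, only, none or still open, it means among the compounds named here.

Measured compounds:
compound 1 `ClCc1ccc(Cn2cnc3nc(Cl)nc(Cl)c32)cc1` — 3160 nM
compound 2 `Nc1nc(Cl)c2ncn(Cc3cccc(CCl)c3)c2n1` — 11700 nM

Both compounds were examined in a functional assay on M14 cells (Homo sapiens) for cytotoxicity, read by sulforhodamine B assay, with a stated time of 48 h; a lower number here means a stronger inhibitor of growth, a higher number a weaker inhibitor of growth. Compound 1 gives 3160 nM, the lower of the two numbers; compound 2 gives 11700 nM, and the gap between them lies beyond the scatter. The two differ in more than one place, so nothing is drawn from the pair beyond what the two values show.

Compound 3 `ClCc1ccc(Cn2cnc3ncnc(Cl)c32)cc1` is not yet measured. It differs from compound 1 by hydrogen in place of chloro on an aromatic carbon, while the benzylic chloromethyl group and the remaining chloro on the core are kept. Within the data shown here, no measured pair shows this single change, so the size of the step is open. A modest weakening beyond the scatter is expected rather than a gain, with the step of a 1.7-fold higher number from compound 1 to compound 3 (0.24 log units; within the scatter) estimated accordingly. For compound 3 the expected value is 5500 nM, within 2000 nM to 16000 nM.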

Compound 3, concentration for total growth inhibition: 13200 nM
Compound 3: the middle estimate sits 2.4-fold (0.38 log units) below what was measured; the range from low to high includes it.
By their numbers in this assay, from the lowest: compound 1; then compounds 2 and 3 (each within the scatter of the next).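

In this assay, hydrogen in place of chloro on the aromatic carbon between two ring nitrogen atoms gives a 4.2-fold higher number from compound 1 to compound 3 (0.62 log units; beyond the scatter). Among these compounds, this is the first single change whose size can be read, and at this position hydrogen does not keep the level seen with chloro. The benzylic chloromethyl group and the remaining chloro group on the core are kept, so the step belongs to this one position, but no measurement shown gives a reason for its size.

From the compounds shown here alone, only chloro and hydrogen can be compared directly at this position, so it remains open how a methyl group, a methoxy group or a fluoro atom would compare there. Also open, going by these compounds, is whether the step keeps its size when a hydroxymethyl group takes the place of the benzylic chloromethyl group.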